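The source may hold more compounds than are shown below. What is called first, only, known or untested is meant among the compounds shown, and "the series" means these compounds.

Within the data shown here, in a functional assay on A549 cells (Homo sapiens) for cytotoxicity, read by sulforhodamine B assay, with a stated time of 72 h (on this read-out lower numbers stand for stronger inhibition of growth and higher numbers for weaker inhibition of growth), compound 1 `Cn1cc(C2CCN=C(N)N2)c2ccccc21` gives 2670 nM, the only number available, so it has no numerical comparator. Compound 2 `COn1cc(C2CCN=C(N)N2)c2ccccc21` is recorded as "not active" (no number reported), without a number. Compound 3 `Cn1cc(C2CCN=C(N)N2)c2cc(Br)ccc21` is compound 1 with one change: bromo in place of hydrogen on an aromatic carbon. Among the measured compounds shown here, no measured step covers this change, so the expectation rests on the structural change alone. The expected step in this assay, a 2.2-fold lower number from compound 1 to compound 3 (0.35 log units; beyond the scatter), is modest and toward stronger inhibition of growth. For compound 3 the estimated value is 1200 nM, with an expected range from 300 nM to 5000 nM.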

Compound 3, concentration for 50% growth inhibition: "not active" (no number reported)
Compound 3 has no reported number here; no gap can be computed for the estimate.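

No new step can be read between compound 1 and compound 3: compound 3 carries no number in this assay to set against compound 1. The compounds shown leave open what bromo on the shared core does to growth inhibition. No supporting data bear on this result.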